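Replacing the fluorophenyl arm: a methyl in its place

The source may hold more compounds than are shown below. What is called first, only, known or untested is meant among the compounds shown, and "the series" means these compounds.

Compound 1 `Cc1cc(C)cc(-c2nnc(COc3cnn(C(C)(C)C)c(=O)c3Cl)s2)c1`: > 300 ug/mL
Compound 2 `CC(C)(C)n1ncc(OCc2nnc(-c3ccccc3F)s2)c(Cl)c1=O`: 121 ug/mL

Of the compounds shown here, two that share one core have been tested in a functional assay on the whole organism for inhibition, with Mythimna separata as the target, with a stated time of 5 days; on this read-out lower numbers stand for an effect already at smaller amounts and higher numbers for an effect only at larger amounts of compound. Compound 1 reaches only a limit of the assay, > 300 ug/mL, and so gives no number. For the measured compounds named here, compound 2 is therefore the only compound with a number in this assay, 121 ug/mL. Going by the values given here, the one other value shown, that of compound 1, is a limit (the limit of > 300 ug/mL in this assay, at which 1 of the 2 values shown sits). Among the compounds with values here, the measured step of an at least 2.4-fold lower number from compound 1 to compound 2 (0.39 log units; beyond the scatter) is the single change on record at this position of the shared core.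

Compound 3 `Cc1cccc(-c2nnc(COc3cnn(C(C)(C)C)c(=O)c3Cl)s2)c1` is not yet measured. It differs from compound 2 in one place: 3-methylphenyl in place of 2-fluorophenyl on an aromatic carbon. Within the data shown here, the 3-methylphenyl that enters is closer in make-up to the 3,5-dimethylphenyl of compound 1 than to the 2-fluorophenyl of compound 2, and the only step on record, an at least 2.4-fold lower number from compound 1 to compound 2 (0.39 log units; beyond the scatter), ran from that dimethyl pattern toward the fluorine with a lower number. Going back toward a methyl pattern is thus expected to move the number up again, though the size can only be read from one step and one limit. The estimate for compound 3 is 230 ug/mL, with a range from 100 ug/mL to 500 ug/mL, which means an expected step of a 1.9-fold higher number from compound 2 to compound 3 (0.28 log units; within the scatter).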

Compound 3, half-maximal effective concentration: > 300 ug/mL
Compound 3: a limit, no number; the forecaster's own chance of this, stated with the estimate: 40%; middle value at least 1.3-fold (0.11 log units) away from the limit.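

In this assay, putting 3-methylphenyl in place of 2-fluorophenyl on this aromatic carbon gives an at least 2.4-fold higher number from compound 2 to compound 3 (0.39 log units; beyond the scatter), so the number of compound 2 is lost with a single methyl group on the phenyl ring. Compound 1 had shown this only with 3,5-dimethylphenyl, and compound 3 now shows that the second methyl group is not needed to reach the limit of the assay. The step between compound 1 and compound 3 cannot be read, since both compounds give only a limit, and compound 2 stays the only one of the three with a number: the limit of > 300 ug/mL in this assay, at which 2 of the 3 values shown sit.

The compounds shown leave open whether the gain in compound 2 goes with the fluorine itself or with where it sits on the phenyl ring, a question that a 3-fluorophenyl or a 2-methylphenyl at this position would address. They also leave open how an unsubstituted phenyl would read here, and how far compound 1 and compound 3 actually lie past their limit.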